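This account rests on a few compounds, and the source may have more. Where it says the series, first, only, none or still open, it means among the compounds named here.

Compound 1 `CCc1cc(S(=O)(=O)N2C[C@H](c3ccccc3)NC2=O)ccc1NC(=O)OC` has the lowest number among the compounds with a numeric value in a functional assay on HCT-116 cells (Homo sapiens) for cytotoxicity, read by MTT assay (on this read-out higher numbers stand for weaker inhibition and lower numbers for stronger inhibition), where compound 1 gives 200 nM. Compound 3 `CCOC(=O)Nc1ccc(S(=O)(=O)N2C(=O)N[C@@H](c3ccccc3)C2C)cc1Cl` gives 5500 nM in this assay, a gap beyond the scatter. Compound 2 `Cc1cc(S(=O)(=O)N2C(=O)N[C@@H](c3ccccc3)C2C)ccc1NC(=O)c1ccc(N)cc1` reaches only the limit of this assay and gives > 10000 nM (the limit of > 10000 nM in this assay, at which 1 of the 3 values shown sits). Compound 4 `CCc1cc(S(=O)(=O)N2C[C@H](c3ccccc3)NC2=O)ccc1NC(=O)NC(C)C` differs from compound 1 by isopropylamino in place of methoxy on a carbonyl carbon, the shared core otherwise unchanged. Going by the values given here, no measured step matches this change, so an expectation rests only on compound 1 with its 200 nM. The expected step of a 1.5-fold higher number from compound 1 to compound 4 (0.18 log units; within the scatter) is estimated to lie within the scatter. The estimate for compound 4 in this assay is 300 nM, between 80 nM and 1500 nM.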

Compound 4, half-maximal inhibitory concentration: 60 nM
For compound 4 the middle estimate is 5.0-fold (0.70 log units) above the measured one; the whole stated range lies above it.
By their numbers in this assay, from the lowest: compound 4; then compound 1; then compound 3. At a limit, above all of these: compound 2.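

At this position, on a carbonyl carbon, the methoxy is not needed for activity in this assay: isopropylamino in its place, with more heavy atoms and a hydrogen-bond donor, gives a 3.3-fold lower number from compound 1 to compound 4 (0.52 log units; beyond the scatter). Going by these compounds alone, this single step turns the (methoxycarbonyl)amino into an (isopropylcarbamoyl)amino and gives the only direct reading of a change at this place. Nothing measured among these compounds accounts for the step. The compounds shown leave open how a plain amino, a methylamino or a longer chain on the same carbonyl carbon would read, and whether the nitrogen or the branched chain carries the step.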